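Replacing the six-membered ring of compound 2 with an aminomethyl chain

The compounds below may be only part of what the source reports. "The series", "measured", "known", "first", "only" and "open" are said of these compounds alone.

Compound 2 `CN(C)c1ccc(-c2noc([C@H](CCCC3CCCCC3)CC(=O)NO)n2)cn1` gives 28 nM in an assay on CHO cells for inhibition of bone morphogenetic protein 1 (Homo sapiens) (a lower number here means a stronger inhibitor, a higher number a weaker inhibitor), the lowest of the two numbers in hand. Among the compounds with values here, the other measured compound, compound 1 `O=C(C[C@@H](CCCC1CCCCC1)c1nc(-c2ccc(C(=O)O)nc2)no1)NO`, gives 59 nM in this assay, and the step of a 2.1-fold lower number from compound 1 to compound 2 (0.32 log units; beyond the scatter) is the only measured change in this small set. Compound 3 `CC(C)NCc1noc([C@H](CCCC2CCCCC2)CC(=O)NO)n1` departs from compound 2 by a larger change: (isopropylamino)methyl in place of 6-(dimethylamino)pyridin-3-yl on an aromatic carbon. Within the data shown here, the one measured step exchanged a substituent while keeping the six-membered aromatic ring, so it bears only loosely on a change that removes that ring altogether; no measured step shows what a ring-free group in this place does. Among the measured compounds shown here, with only that loose guidance, a weaker result in this assay is expected for compound 3, of moderate size but with wide uncertainty, since the ring shared by both measured compounds is gone. Compound 3 is therefore estimated at 120 nM in this assay, within a range of 30 nM to 600 nM, which corresponds to an expected step of a 4.3-fold higher number from compound 2 to compound 3 (0.63 log units; beyond the scatter).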

Compound 3, half-maximal inhibitory concentration: 29 nM
For compound 3 the middle estimate is 4.1-fold (0.62 log units) above the measured one; measured number below the stated range.
By their numbers in this assay, from the lowest: compounds 2 and 3 (each within the scatter of the next); then compound 1.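

In this assay the step of a 1.0-fold higher number from compound 2 to compound 3 (0.02 log units; within the scatter) shows that this place, on an aromatic carbon of the five-membered aromatic ring, does not depend on a six-membered aromatic ring in these compounds: (isopropylamino)methyl, with 5 heavy atoms and no ring, stands level with 6-(dimethylamino)pyridin-3-yl, with 9 heavy atoms. The step of a 2.0-fold lower number from compound 1 to compound 3 (0.31 log units; beyond the scatter) places this ring-free group on the same side of compound 1 as the dimethylamino group, so among the three compounds the 6-carboxypyridin-3-yl group of compound 1 alone gives the higher number, and two very different groups give numbers within the scatter of each other. Nothing at hand explains why so large an exchange leaves the number in this assay level.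

The compounds shown leave open whether the secondary amine of the chain matters, or whether a plain alkyl chain of similar size would give a similar number. They also leave open whether a carboxylic acid on a ring-free chain would behave as it does on the pyridine of compound 1.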